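The source may report more compounds than this note shows. Statements on the series, on what has been measured and on what is new or still open speak of the compounds shown alone.

For the measured compounds named here, in a functional assay on T-24 cells (Homo sapiens) for antiproliferative activity, read by MTT assay, with a stated time of 72 h (on this read-out higher numbers stand for weaker inhibition and lower numbers for stronger inhibition), compound 1 (`CC(C)CNC(=N)NC(=N)Nc1ccc(F)c(F)c1`) gives 42900 nM, the higher of the two numbers so far, while compound 2 (`CCN(CC)C(=N)NC(=N)Nc1ccc(C(F)(F)F)cc1`) gives 6200 nM and inhibits more strongly. Compound 3 (`N=C(NC(=N)NC1CCCC1)Nc1ccc(F)c(F)c1`) has cyclopentyl in place of isobutyl on an amine nitrogen. Going by the values given here, no measured pair shows this change, so the expectation starts from compound 1 at 42900 nM and foresees a small move in this assay towards stronger inhibition, perhaps none beyond the scatter. The estimate means a step (a 1.4-fold lower number from compound 1 to compound 3 (0.16 log units; within the scatter)) of modest size. Compound 3 is expected to give 30000 nM (range 11000 nM to 75000 nM) as a rough estimate.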

Compound 3, half-maximal inhibitory concentration: 24900 nM
Compound 3: the middle estimate sits 1.2-fold (0.08 log units) above what was measured, and the stated range covers the measured number.
By their numbers in this assay, from the lowest: compound 2; then compounds 3 and 1 (each within the scatter of the next).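

In this assay, for the compounds shown here, the one pair that differs in a single place shows a 1.7-fold lower number from compound 1 to compound 3 (0.24 log units; within the scatter), so cyclopentyl in place of isobutyl on an amine nitrogen gives no change that can be told apart from the scatter. At this position, a five-membered non-aromatic ring of carbon only and the open isobutyl chain thus read alike on the shared core. Nothing measured here explains this result. From the compounds shown here alone, whether a phenyl ring, a hydroxyethyl chain or a longer alkyl chain on this nitrogen would move the number stays open.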